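A methyl swap on a compound stuck at the limit

This account rests on a few compounds, and the source may have more. Where it says the series, first, only, none or still open, it means among the compounds named here.

In a functional assay on A549 cells (Homo sapiens), read by MTT assay, with a stated time of 72 h (on this read-out lower numbers stand for stronger inhibition and higher numbers for weaker inhibition), compound 3 `C#Cc1cn([C@@H]2O[C@H](CO)[C@@H](O)[C@H]2O)c2ncnc(NC)c12` gives > 20000 nM, which is a limit and not a number. Compound 1 `CNc1ncnc2c1c(-c1cccs1)cn2[C@@H]1O[C@H](CO)[C@@H](O)[C@H]1O` gives > 20000 nM, also a limit. Compound 2 `CNc1ncnc2c1c(-c1ccsc1)cn2[C@@H]1O[C@H](CO)[C@@H](O)[C@H]1O` gives > 20000 nM, again a limit. All the data so far therefore stand at the limit of > 20000 nM in this assay, at which 3 of the 3 values shown sit, and compound 3 has no readable rank in the series.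

Compound 4 `C#Cc1cn([C@@H]2O[C@H](CO)[C@@H](O)[C@H]2O)c2ncnc(C)c12` differs from compound 3 in one place: methyl in place of methylamino on an aromatic carbon. The change sits on an aromatic carbon next to the ring nitrogen.

The measured steps are a step that the two limits leave unreadable from compound 1 to compound 2, a step that the two limits leave unreadable from compound 1 to compound 3 and a step that the two limits leave unreadable from compound 2 to compound 3. None of them touches methylamino, and none gives a size to carry over. With so little to go on, only a modest gain in strength is expected, and another limit is about as likely as a number. The expected change is an at least 1.3-fold lower number from compound 3 to compound 4 (0.12 log units; that floor lies within the scatter). Compound 4 is estimated at 15000 nM, with an expected range from 2000 nM to 30000 nM.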

Compound 4, half-maximal inhibitory concentration: 19200 nM
Beside the measured number, compound 4's estimate is 1.3-fold (0.11 log units) below it; low and high end bracket the measured number.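

In this assay, within the data shown here, compound 4 is the first compound here to give a number rather than a limit, so methyl in place of methylamino, on this aromatic carbon next to the ring nitrogen, moves the series onto a readable scale. Compound 3 gives only a limit, so the change can be stated only as an at least 1.0-fold lower number from compound 3 to compound 4 (0.01 log units; that floor lies within the scatter) and its floor does not go beyond the usual scatter. Losing methylamino, with its hydrogen-bond donor and acceptor, therefore causes no readable loss of strength, but no reliable gain is shown either.

The steps among compound 1, compound 2 and compound 3 cannot be read, and most of the data stay at one bound: the limit of > 20000 nM in this assay, at which 3 of the 4 values shown sit. As far as these compounds go, whether dimethylamino, a chlorine atom or a longer chain such as ethyl at this position would give a clearly lower number remains open.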